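Trimming the Sulfonyl Chain: Expected Stability of Compound 4

This account rests on a few compounds, and the source may have more. Where it says the series, first, only, none or still open, it means among the compounds named here.

Measured in an ADME assay on microsomes from liver (Homo sapiens) for metabolic stability, with a stated time of 10 min; a higher number here means that more of the compound is left, a lower number that less of the compound is left:
Compound 1 `CC(C)NCCS(=O)(=O)NC(=O)c1ccc(Nc2nc(NC3(c4ccc(Cl)cc4)CC3)nc(OCC(F)(F)F)n2)cc1` gives 89%.
Compound 2 `CCS(=O)(=O)NC(=O)c1ccc(Nc2nc(NC3(c4ccc(Cl)cc4)CC3)nc(OCC(F)(F)F)n2)cc1` gives 100%.
Compound 3 `CC(C)(C)CNCCS(=O)(=O)NC(=O)c1ccc(Nc2nc(NC3(c4ccc(Cl)cc4)CC3)nc(OCC(F)(F)F)n2)cc1` gives 89%.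

Compound 3 stands level with compound 1 at the digits shown, and together they are the lowest of the three; compound 2 stands apart, with a number 11 percentage points lower from compound 2 to compound 3 (beyond the scatter).

Compound 4 `O=C(NS(=O)(=O)C1CC1)c1ccc(Nc2nc(NC3(c4ccc(Cl)cc4)CC3)nc(OCC(F)(F)F)n2)cc1` differs from compound 3 by cyclopropyl in place of 2-(neopentylamino)ethyl on a sulfonyl sulfur. For the measured compounds named here, two measured steps bear on this: a number 11 percentage points higher from compound 1 to compound 2 (beyond the scatter) and a number 11 percentage points lower from compound 2 to compound 3 (beyond the scatter), each a removal or addition of an amine-bearing chain at the sulfonyl sulfur. Because a number 11 percentage points lower from compound 2 to compound 3 (beyond the scatter) and a number 11 percentage points higher from compound 1 to compound 2 (beyond the scatter) both move in the same sense as the chain leaves or enters, compound 4 is expected to show a modest rise in this assay, a number 8 percentage points higher from compound 3 to compound 4 (within the scatter). Compound 4 is therefore estimated at 97%, in the range 85% to 100%.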

Compound 4, percent of the compound remaining: 100%
Compound 4: the middle estimate sits 3 percentage points below what was measured; the measured number falls inside the stated range.
By their numbers in this assay, from the lowest: compounds 1 and 3 (each within the scatter of the next); then compounds 2 and 4 (each within the scatter of the next).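

In this assay, the position on the sulfonyl sulfur now also carries a ring, and cyclopropyl in place of ethyl gives no change at the digits printed from compound 2 to compound 4 (within the scatter). Replacing either amine-bearing chain with cyclopropyl gives the same modest step, a number 11 percentage points higher from compound 3 to compound 4 (beyond the scatter) and a number 11 percentage points higher from compound 1 to compound 4 (beyond the scatter), so the earlier gap recurs with a second group lacking the amine. No measured evidence accounts for these steps.

From the compounds shown here alone, it remains open whether a longer chain without an amine, or a chain ending in a carboxylic acid, would match compound 4 or compound 1.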